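The source may hold more compounds than are shown below. What is called first, only, known or untested is meant among the compounds shown, and "the series" means these compounds.

Measured compounds:
compound 1, `N=C(N)c1ccc(-c2ccc(-c3ccc(Cl)cc3)s2)s1`, gives 1440 nM in a functional assay on COLO 205 cells (Homo sapiens) for inhibition, read by sulforhodamine B assay, with a stated time of 48 h; on this read-out lower numbers stand for stronger inhibition of growth and higher numbers for weaker inhibition of growth.
compound 2, `COc1cc(OC)cc(-c2ccc(-c3ccc(C(=N)N)o3)o2)c1`, gives 1840 nM in this assay.
compound 3, `N=C(N)c1ccc(-c2ccc(-c3ccc4ccccc4c3)s2)s1`, gives 1630 nM in this assay.

Of the three numbers, compound 1 holds the lowest. Compound 3 stands nearest to it and compound 2 furthest, yet both gaps lie within the usual scatter of repeated measurements, so the three compounds cannot be put in any order of potency on what has been measured, and none of them can be called the strongest.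

Compound 4, `N=C(N)c1ccc(-c2ccc(-c3ccc(F)cc3)s2)s1`, has not yet been measured. It differs from compound 1 in one place: fluoro in place of chloro on an aromatic carbon. One heavy atom leaves and one heavy atom enters, on an aromatic carbon of a six-membered aromatic ring of carbon only, and the shared core of compound 1 stays as it is.

For the measured compounds named here, no two measured compounds differ in a single place, so there is no measured step to lean on. With an exchange of this size the expectation in this assay is a step that does not go beyond the scatter, in either direction. The step from compound 1 to compound 4 is therefore estimated as a 1.3-fold higher number from compound 1 to compound 4 (0.10 log units; within the scatter). For compound 4 the estimate is 1800 nM, with a range from 700 nM to 4500 nM.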

Compound 4, concentration for 50% growth inhibition: 1320 nM
Compound 4: middle estimate off by 1.4-fold (0.13 log units), on the high side, and the stated range covers the measured number.
By their numbers in this assay, from the lowest: compounds 4, 1, 3 and 2 (each within the scatter of the next).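

In this assay the series now has a step that differs in one place: with fluoro in place of chloro on an aromatic carbon of a six-membered aromatic ring of carbon only, para to a large group, the result is a 1.1-fold lower number from compound 1 to compound 4 (0.04 log units; within the scatter) and the shared core stays unchanged. At this position, therefore, the two halogens cannot be told apart on this read-out, and the exchange of one heavy atom for another leaves no readable effect on growth inhibition. Nothing at hand speaks to why the two compounds read alike.

On these data alone, this single step says only that chloro and fluoro cannot be separated here, not how far the position would accept something different, so the outcome with a methoxy group, an amine or a carboxylic acid on the same aromatic carbon remains open. Also open, as far as these compounds go, is whether the same exchange of chloro for fluoro would stay within the scatter on a different core, since it is seen here on the core of compound 1 alone.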